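Aryl sulfonylacetic acid ethers: exchanging the distal aryl group

The source may report more compounds than this note shows. Statements on the series, on what has been measured and on what is new or still open speak of the compounds shown alone.

Compound 1 `COc1cc(C)c(-c2cccc(COc3ccc4c(c3)S(=O)(=O)CC4CC(=O)O)c2)c(C)c1` has a different core from the others. In a functional assay on CHO cells for agonist activity at Free fatty acid receptor 1 (Homo sapiens), read by FLIPR and calcium flux (on this read-out lower numbers stand for an effect already at smaller amounts and higher numbers for an effect only at larger amounts of compound), compound 1 gives only a limit, > 1000 nM. Compound 2 `Cc1ccccc1-c1cccc(COc2ccc(S(=O)(=O)CC(=O)O)cc2)c1` carries the open core; in this assay compound 2 gives 46.8 nM. Compound 3 `O=C(O)CS(=O)(=O)c1ccc(OCc2cccc(-c3ccccc3C(F)(F)F)c2)cc1` in this assay gives 52.5 nM. Of the two numbers shown, compound 3 holds the higher one, with compound 2 nearest and the gap within the scatter.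

Compound 4 `Cc1ccc(-c2cccc(COc3ccc(S(=O)(=O)CC(=O)O)cc3)c2)c(Cl)c1` is not yet measured. It differs from compound 3 by 2-chloro-4-methylphenyl in place of 2-(trifluoromethyl)phenyl on an aromatic carbon. Within the data shown here, only one measured step bears on this change, the exchange of the group on the aromatic carbon at the same place between compound 2 and compound 3, and that step was a 1.1-fold higher number from compound 2 to compound 3 (0.05 log units; within the scatter). The change to compound 4 is of the same kind, a swap of the substitution on that ring, so no step beyond the scatter is expected in this assay for compound 4, in either direction. Compound 4 is accordingly expected to give 50 nM in this assay, with a range from 20 nM to 150 nM. The step this estimate implies, a 1.1-fold lower number from compound 3 to compound 4 (0.02 log units; within the scatter), is expected to stay within the scatter.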

Compound 4, half-maximal effective concentration: 36.3 nM
Compound 4: middle estimate off by 1.4-fold (0.14 log units), on the high side; the measured number falls inside the stated range.
By their numbers in this assay, from the lowest: compounds 4, 2 and 3 (each within the scatter of the next). At a limit, above all of these: compound 1.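

Working notes on the position, an aromatic carbon meta to a large group, in this assay: a 1.4-fold lower number from compound 3 to compound 4 (0.16 log units; within the scatter) and a 1.3-fold lower number from compound 2 to compound 4 (0.11 log units; within the scatter) leave the new group level with both earlier ones. Among these compounds, the earlier pair showed only one single-substituent group exchanged for another; 2-chloro-4-methylphenyl brings chlorine and a second substituent on the ring, yet the read-out does not separate it from 2-methylphenyl or 2-(trifluoromethyl)phenyl, and the smaller count of heavy atoms in the entering group leaves no mark either. Among these three compounds, then, the position accepts the change without a step beyond the scatter, and nothing measured in this set offers a reason for that.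

Open, going by these compounds, is whether this level read-out extends to groups of another kind on the same ring, such as an amine, a carboxylic acid or a nitrile, or to a longer chain in place of the methyl. Also open is what an unsubstituted phenyl at this place would give, as each of the three groups shown carries a substituent on the ring.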